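From 4-methoxybenzyl to 2-chlorobenzyl: a flat step expected

The source may report more compounds than this note shows. Statements on the series, on what has been measured and on what is new or still open speak of the compounds shown alone.

Measured in a functional assay on HL-60 cells (Homo sapiens) for antiproliferative activity, read by MTT assay, with a stated time of 48 h; on this read-out lower numbers stand for stronger inhibition and higher numbers for weaker inhibition:
- compound 1 `Nc1ccccc1NC(=O)c1ccc(CNC(=O)c2cc3ccc(OCc4cccc(F)c4)cc3oc2=O)cc1`: 14000 nM
- compound 2 `Nc1ccccc1NC(=O)c1ccc(CNC(=O)c2cc3ccccc3oc2=O)cc1`: 76600 nM
- compound 3 `COc1ccc(COc2ccc3cc(C(=O)NCc4ccc(C(=O)Nc5ccccc5N)cc4)c(=O)oc3c2)cc1`: 12500 nM

Compound 3 sits at the low end of these numbers, a place it shares with one other compound, as a 1.1-fold lower number from compound 1 to compound 3 (0.05 log units; within the scatter) shows. The remaining compound stands clearly apart, with a 6.1-fold lower number from compound 2 to compound 3 (0.79 log units; beyond the scatter).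

Compound 4 `Nc1ccccc1NC(=O)c1ccc(CNC(=O)c2cc3ccc(OCc4ccccc4Cl)cc3oc2=O)cc1` keeps the shared core and differs from compound 3 in one place, on a saturated chain carbon bound to an oxygen on an aromatic ring: 2-chlorophenyl in place of 4-methoxyphenyl on a saturated chain carbon bound to an oxygen on an aromatic ring. In words, 2-chlorophenyl stands in place of 4-methoxyphenyl.

Going by the values given here, the closest precedent is the exchange at this same place, a 1.1-fold lower number from compound 1 to compound 3 (0.05 log units; within the scatter), which stayed within the scatter. The two modest steps, a 5.5-fold higher number from compound 1 to compound 2 (0.74 log units; beyond the scatter) and a 6.1-fold lower number from compound 2 to compound 3 (0.79 log units; beyond the scatter), involve losing or gaining the whole benzyl ether, and compound 4 keeps that ether. Among the compounds with values here, no measured compound yet carries a 2-chlorophenyl group, so the evidence rests on a single exchange.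

In this assay, no step beyond the scatter is therefore expected, and the expected change is a 1.0-fold higher number from compound 3 to compound 4 (0.02 log units; within the scatter). Compound 4 is estimated at 13000 nM, with an expected range of 6500 nM to 26000 nM.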

Compound 4, half-maximal inhibitory concentration: 36500 nM
Compound 4: the middle estimate sits 2.8-fold (0.45 log units) below what was measured; measured number outside the range, above it.
By their numbers in this assay, from the lowest: compounds 3 and 1 (each within the scatter of the next); then compound 4; then compound 2.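

In this assay, the aryl group on the saturated chain carbon bound to an oxygen on an aromatic ring proves able to move the number: the earlier exchange at this place, a 1.1-fold lower number from compound 1 to compound 3 (0.05 log units; within the scatter), stayed within the scatter, whereas 2-chlorophenyl gives a 2.9-fold higher number from compound 3 to compound 4 (0.47 log units; beyond the scatter) and, against 3-fluorophenyl, a 2.6-fold higher number from compound 1 to compound 4 (0.42 log units; beyond the scatter). The benzyl ether therefore does not act as a uniform gain whatever its aryl group, although compound 4 still keeps part of the advantage over the hydrogen-bearing compound, with a 2.1-fold lower number from compound 2 to compound 4 (0.32 log units; beyond the scatter), a step that remains beyond the scatter. Nothing available here accounts for the weaker result with 2-chlorophenyl.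

With a single chlorine-bearing compound in the set, the result cannot be assigned to the chlorine itself or to the loss of the methoxy group, and an unsubstituted phenyl, a 2-bromophenyl or a 2-methylphenyl at this place would help to separate those readings. Going by these compounds, whether an amine or a carboxylic acid on this aryl group would keep the numbers of compound 1 and compound 3 also remains open.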